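Dropping a Methyl: from Compound 2 to Compound 3

The source may report more compounds than this note shows. Statements on the series, on what has been measured and on what is new or still open speak of the compounds shown alone.

Both compounds with numbers sit at the edge of what a functional assay for inhibition, with Homo sapiens as the target (a lower number here means a stronger inhibitor, a higher number a weaker inhibitor), can report. Compound 1 `Sc1nncc2cncn12` gives > 48000 nM in this assay, a limit rather than a number. Compound 2 `COCc1nc(C)c2cnnc(S)n12` gives > 48000 nM in this assay, again a limit. Compound 2 thus stands where every value shown stands, namely at the limit of > 48000 nM in this assay, at which 2 of the 2 values shown sit. Compound 3 `COCc1ncc2cnnc(S)n12` differs from compound 2 in one place: hydrogen in place of methyl on an aromatic carbon. Going by the values given here, no measured step between close neighbours exists to size such a change, and compound 1, which also lacks a methyl there but differs in more than one place, likewise sits at the limit. For this assay the expected step that the limit leaves unreadable from compound 2 to compound 3 is none beyond the scatter. Compound 3 is expected to give 60000 nM in this assay, within 20000 nM to 200000 nM, most likely again only as a limit.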

Compound 3, half-maximal inhibitory concentration: > 48000 nM
Compound 3 ended at the assay's limit; the forecaster's own chance of this, stated with the estimate: 85%; the middle value is on the limit's open side.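

Going by these compounds alone, no step among compound 1, compound 2 and compound 3 can be read, as all three stand at one limit: the limit of > 48000 nM in this assay, at which 3 of the 3 values shown sit. The compounds shown leave open whether a methyl or a methoxymethyl group on the aromatic carbon makes any difference to inhibition.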